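A few compounds are considered here, and "the series" means these few. Any claim that something is new, unique, unknown or untested is made for them only; others in the source may bear on it.

Of the compounds shown here, three sharing one core have been measured in a functional assay (aorta) with Rattus norvegicus as the target; on this read-out higher numbers stand for weaker inhibition and lower numbers for stronger inhibition. Compound 1 `CC1(C)Oc2ccc(C#N)cc2[C@@H](/N=C(\NC#N)Sc2ccccc2)[C@@H]1O` gives 4900 nM, the highest number of the three. Compound 2 `COC(=O)c1cn([C@@H]2c3cc(C#N)ccc3OC(C)(C)[C@H]2O)c2ccccc12` gives 500 nM, and compound 3 `CC1(C)Oc2ccc(C#N)cc2[C@@H](n2cc(C#N)c3ccccc32)[C@@H]1O` gives 2200 nM; compound 1 therefore shows the weakest inhibition among the three measured compounds. Going by the values given here, the one step between two compounds that differ in a single place, a 4.4-fold higher number from compound 2 to compound 3 (0.64 log units; beyond the scatter), concerns a group on a ring that compound 1 does not carry, so it says nothing direct about the change considered here.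

Compound 4 `CC(=O)c1ccc(N/C(=N/[C@@H]2c3cc(C#N)ccc3OC(C)(C)[C@H]2O)NC#N)cc1` has not yet been measured. Among the compounds with values here, it differs from compound 1 in one place: (4-acetylphenyl)amino in place of phenylsulfanyl on a carbon with a double bond to nitrogen No measured step covers this kind of exchange, so there is no observed step to lean on, and any expectation remains uncertain. For compound 4 the expected value in this assay is 1500 nM, with a likely range from 400 nM to 6000 nM. This would be an expected step of a 3.3-fold lower number from compound 1 to compound 4 (0.51 log units; beyond the scatter), toward stronger inhibition.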

Compound 4, half-maximal inhibitory concentration: 21000 nM
Beside the measured number, compound 4's estimate is 14-fold (1.15 log units) below it; measured number outside the range, above it.
By their numbers in this assay, from the lowest: compound 2; then compound 3; then compound 1; then compound 4.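

The carbon with a double bond to nitrogen is sensitive to what it carries: in this assay this exchange gives a 4.3-fold higher number from compound 1 to compound 4 (0.63 log units; beyond the scatter), a step toward weaker inhibition and beyond the usual scatter. The exchange alters two things at once, since an amine nitrogen carrying a hydrogen-bond donor replaces the sulfur and an acetyl group appears on the aromatic ring, so the step belongs to the whole swap and not to either part alone. Nothing measured here explains why the number rises.

Which of the two parts accounts for the step remains open, and a plain phenylamino group on the same carbon would separate them. Also open, from the compounds shown here alone, is how a carboxylic acid in place of the acetyl group would read out.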